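Replacing 4-methylbenzyl with 4-methoxybenzyl in the series

This account rests on a few compounds, and the source may have more. Where it says the series, first, only, none or still open, it means among the compounds named here.

Measured in a functional assay on MCF7 cells (Homo sapiens) for inhibition, read by CCK-8 assay, with a stated time of 48 h; a higher number here means a weaker inhibitor of growth, a lower number a stronger inhibitor of growth:
- compound 1 `CN1CCN(c2ccc(Nc3ncc(Cl)c(Nc4ccccc4)n3)nc2)CC1`: 51800 nM
- compound 2 `CN1CCN(c2ccc(Nc3ncc(Cl)c(NCc4ccccc4)n3)nc2)CC1`: 17300 nM
- compound 3 `Cc1ccc(CNc2nc(Nc3ccc(N4CCN(C)CC4)cn3)ncc2Cl)cc1`: 38100 nM

Compound 3 lies within the scatter of compound 1 (a 1.4-fold lower number from compound 1 to compound 3 (0.13 log units; within the scatter)), while compound 2 has the lowest number (a 2.2-fold higher number from compound 2 to compound 3 (0.34 log units; beyond the scatter)). Compound 4 `COc1ccc(CNc2nc(Nc3ccc(N4CCN(C)CC4)cn3)ncc2Cl)cc1` carries methoxy in place of methyl on an aromatic carbon, para to a large group (methoxy in place of methyl on an aromatic carbon). Among the measured compounds shown here, only one measured step concerns a substituent at this place, the modest 2.2-fold higher number from compound 2 to compound 3 (0.34 log units; beyond the scatter), and no methoxy compound has been measured yet. No step beyond the scatter is therefore expected in this assay. The expected change is a 1.2-fold lower number from compound 3 to compound 4 (0.08 log units; within the scatter). The estimate for compound 4 is 32000 nM, within an expected range of 15000 nM to 60000 nM.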

Compound 4, concentration for 50% growth inhibition: 17300 nM
Compound 4: the middle estimate sits 1.8-fold (0.27 log units) above what was measured; the measured number falls inside the stated range.
By their numbers in this assay, from the lowest: compounds 2 and 4 (each within the scatter of the next); then compounds 3 and 1 (each within the scatter of the next).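

In this assay, the aromatic carbon para to a large group separates methyl from methoxy (a 2.2-fold lower number from compound 3 to compound 4 (0.34 log units; beyond the scatter)), a step of the same printed size as the opposite one from hydrogen to methyl (a 2.2-fold higher number from compound 2 to compound 3 (0.34 log units; beyond the scatter)). Methoxy and hydrogen do not separate here (no change at the digits printed from compound 2 to compound 4 (within the scatter)), so methyl stands apart among these three, while 4-methoxybenzyl remains ahead of phenyl on the nitrogen (a 3.0-fold lower number from compound 1 to compound 4 (0.48 log units; beyond the scatter)). Nothing available explains the methyl result.

Open, from the compounds shown here alone, is whether an amine or a carboxylic acid at this carbon would separate from hydrogen. Also open, going by these compounds, is how a longer chain in place of the benzyl link would read.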